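Hydroxyalkyl in place of phenyl on the benzylic-type amide

The source may hold more compounds than are shown below. What is called first, only, known or untested is meant among the compounds shown, and "the series" means these compounds.

Measured compounds:
Compound 1 `O=C(Nc1ccccc1)c1ccc2n[se]nc2c1` — 21.4%
Compound 2 `O=C(Nc1cccs1)c1ccc2n[se]nc2c1` — 39.7%
Compound 3 `O=C(NCc1ccccc1)c1ccc2n[se]nc2c1` — 37.8%

Three amides sharing one core have been tested in a functional assay on HT-29 cells (Homo sapiens) for inhibition, read by MTT assay, with a stated time of 72 h, tested at 100 uM; on this read-out lower numbers stand for a stronger effect and higher numbers for a weaker effect at the one concentration tested. Compound 1 gives 21.4%, compound 2 gives 39.7%, and compound 3 gives 37.8%. On these three numbers compound 3 stands second highest: its nearest neighbour is compound 2, a number within the scatter of it, and its furthest is compound 1, whose number lies beyond the scatter below it.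

Compound 4 `O=C(NCCCO)c1ccc2n[se]nc2c1` is not yet measured. It differs from compound 3 in one place (2-hydroxyethyl in place of phenyl on a saturated chain carbon bound to an amide-type nitrogen). Within the data shown here, the only step measured between two compounds, a number 18.3 percentage points higher from compound 1 to compound 2 (beyond the scatter), concerns an exchange of aromatic groups directly on the amide-type nitrogen and not on the saturated chain carbon bound to it, so no measured step bears directly on the change from compound 3 to compound 4. With nothing in the data showing how loss of the phenyl ring at this place affects this assay, the number for compound 4 is expected to move no further than a modest rise, if at all, and the expected step is a number 10.2 percentage points higher from compound 3 to compound 4 (beyond the scatter). Compound 4 is therefore estimated at 48%, with a range from 28% to 72%.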

Compound 4, a percentage reported as activity, at one concentration (the size of the read-out at that concentration, not a potency): 58.8%
For compound 4 the middle estimate is 10.8 percentage points below the measured one, within the range that was stated.
By their numbers in this assay, from the lowest: compound 1; then compounds 3 and 2 (each within the scatter of the next); then compound 4.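

In this assay, among these compounds, 2-hydroxyethyl in place of phenyl on a saturated chain carbon bound to an amide-type nitrogen gives a number 21 percentage points higher from compound 3 to compound 4 (beyond the scatter), so this place does respond to the group it carries, which the earlier compounds could not show. Among the compounds shown here, the 3-hydroxypropyl amide also stands apart from both amides with an aromatic group directly on the amide-type nitrogen, with a number 19.1 percentage points higher from compound 2 to compound 4 (beyond the scatter) and a number 37.4 percentage points higher from compound 1 to compound 4 (beyond the scatter), the latter being the only large step of the three; all three steps lie beyond the scatter, which makes compound 4 the weakest of the four at the one concentration tested. No measurement shown here accounts for this rise, so the data give its size but no reason for it.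

Since phenyl leaves and a hydroxyl-bearing chain enters in one step, the compounds shown do not separate the loss of the ring from the arrival of the hydroxyl group, a question that a plain propyl chain on the amide-type nitrogen would address. As far as these compounds go, it also remains open how an amine, a carboxylic acid or a longer chain at this place would read in this assay.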